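Dichlorophenyl ureas at the cytotoxicity limit

The source may report more compounds than this note shows. Statements on the series, on what has been measured and on what is new or still open speak of the compounds shown alone.

Measured in an ADME assay on HS27 cells (Homo sapiens) for cytotoxicity, read by MTT assay, with a stated time of 24 h; on this read-out higher numbers stand for weaker inhibition of growth and lower numbers for stronger inhibition of growth:
- compound 1 `Cc1ccc(NC(=O)Nc2cccc(Cl)c2)cc1NC(=O)c1cnoc1C`: > 30000 nM (a limit)
- compound 2 `Cc1ccc(NC(=O)Nc2cc(Cl)cc(Cl)c2)cc1NC(=O)c1cnoc1C`: > 30000 nM (a limit)

Compound 2 gives > 30000 nM in this assay, which is a limit of the assay and not a number. Both measured compounds stand at the limit of > 30000 nM in this assay, at which 2 of the 2 values shown sit.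

Compound 3 `Cc1ccc(NC(=O)Nc2ccc(Cl)c(Cl)c2)cc1NC(=O)c1cnoc1C` follows from compound 2 by one change: 3,4-dichlorophenyl in place of 3,5-dichlorophenyl on an amide-type nitrogen. In words, 3,4-dichlorophenyl replaces 3,5-dichlorophenyl on an amide-type nitrogen.

Among the measured compounds shown here, the only measured step that bears on this is a step that the two limits leave unreadable from compound 1 to compound 2, and it offers no size to carry over. No step beyond the scatter is expected in this assay, in either direction, because of the limit of > 30000 nM in this assay, at which 2 of the 2 values shown sit. Another report as a limit is the likeliest outcome.

The expected step is a number no higher from compound 2 to compound 3 (the limit leaves the size open). Compound 3 is estimated at 30000 nM, with an expected range of 12000 nM to 60000 nM.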

Compound 3, concentration for 50% growth inhibition: > 30000 nM
Compound 3: a limit, no number (the forecaster's own chance of this, stated with the estimate: 70%); the middle value lies on the limit itself.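

In this assay compound 3 gives > 30000 nM, a limit of the assay and not a number. No step among compound 1, compound 2 and compound 3 can be read: the limit of > 30000 nM in this assay, at which 3 of the 3 values shown sit.

The compounds shown leave open whether swapping 3,5-dichlorophenyl for 3,4-dichlorophenyl changes growth inhibition at all in this assay.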